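A few compounds are considered here, and "the series" means these few. Any claim that something is new, unique, unknown or untested is made for them only; others in the source may bear on it.

Working notes on the series.

Compound 1 `CNC(=O)/C=C/c1ccncc1-c1ccc2ccccc2c1` in a functional assay on A549 cells (Homo sapiens) for inhibition, read by sulforhodamine B assay, with a stated time of 72 h (a higher number here means a weaker inhibitor of growth, a lower number a stronger inhibitor of growth), gives 6620 nM. Compound 2 `O=C(O)/C=C/c1ccncc1-c1ccc2ccccc2c1` in this assay gives only a limit, > 10000 nM. Compound 3 `Cn1ccc2cc(-c3cnccc3/C=C/C(=O)O)ccc21` likewise gives only a limit, > 10000 nM. The change from compound 2 to compound 1 is methylamino in place of hydroxy on a carbonyl carbon and gives an at least 1.5-fold lower number from compound 2 to compound 1 (0.17 log units; that floor lies within the scatter); its floor rests on (the limit of > 10000 nM in this assay, at which 2 of the 3 values shown sit). Compound 4 `CNC(=O)/C=C/c1ccncc1-c1ccc2c(ccn2C)c1`, not yet measured, carries the same change on the core of compound 3: methylamino in place of hydroxy on a carbonyl carbon. How the core of compound 3 differs from that of compound 2 is not broken down here.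

The step from compound 3 to compound 4 in this assay is expected to be an at least 1.2-fold lower number from compound 3 to compound 4 (0.09 log units; that floor lies within the scatter), resting on compound 2 to compound 1 having shown an at least 1.5-fold lower number from compound 2 to compound 1 (0.17 log units; that floor lies within the scatter). Compound 4 is therefore estimated at 8000 nM, between 3000 nM and 30000 nM.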

Compound 4, concentration for 50% growth inhibition: 6450 nM
Estimate against measurement, compound 4: 1.2-fold (0.09 log units) above, within the range that was stated.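

Carried to the core of compound 3, the change of hydroxy to methylamino on a carbonyl carbon gives an at least 1.5-fold lower number from compound 3 to compound 4 (0.19 log units; that floor lies within the scatter) in this assay. This is compatible with the change behaving alike on both cores, but neither step has a measured size, so no equal carry-over is shown: the same change on two cores in this assay, an at least 1.5-fold lower number (0.17 log units; that floor lies within the scatter) from compound 2 to compound 1 and an at least 1.5-fold lower number (0.19 log units; that floor lies within the scatter) from compound 3 to compound 4; the limit leaves it open whether they differ The floors of both steps are set by a limit of the assay and not by a measured number: the limit of > 10000 nM in this assay, at which 2 of the 4 values shown sit.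

The compounds shown leave open how a primary amide, a dimethylamide or a methyl ester on the same carbonyl carbon would read in this assay. They also leave open whether an amine in place of the carboxy group would give a measurable value on either core.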